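This account rests on a few compounds, and the source may have more. Where it says the series, first, only, none or still open, it means among the compounds named here.

Working notes on the series in a functional assay on PC-3 cells (Homo sapiens) for inhibition, read by sulforhodamine B assay, with a stated time of 72 h; on this read-out higher numbers stand for weaker inhibition and lower numbers for stronger inhibition.

Compound 1 `Nc1sc(-c2ccc(Cl)cc2)c(-c2ccc(Cl)cc2)c1C(=O)NC1CCC1` carries a cyclobutyl group on the amide-type nitrogen and in this assay compound 1 gives 24800 nM. Among the three entries in this assay it is the only one with a definite number. Compound 2 `Nc1sc(-c2ccc(Cl)cc2)c(-c2ccc(Cl)cc2)c1C(=O)Nc1ccccc1`, with phenyl in place of cyclobutyl on the amide-type nitrogen, reaches only a limit of the assay in this assay, where compound 2 is reported as > 50000 nM; this is the same limit as the limit of > 50000 nM in this assay, at which 1 of the 3 values shown sits. The step of an at least 2.0-fold higher number from compound 1 to compound 2 (0.30 log units; that floor lies within the scatter) is therefore known only as a floor. Compound 3 `CCN(CC)CCNC(=O)Nc1sc(-c2ccc(Cl)cc2)c(-c2ccc(Cl)cc2)c1C(=O)NC1CC1`, a urea analogue bearing a cyclopropyl group on the amide-type nitrogen, has no result in this assay, where compound 3 stands as "not determined" (no result reported).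

The step now followed runs from compound 1 to compound 4 `Nc1sc(-c2ccc(Cl)cc2)c(-c2ccc(Cl)cc2)c1C(=O)NC1CC1`: cyclopropyl in place of cyclobutyl on an amide-type nitrogen. Among the compounds with values here, no measured step concerns this exchange; the only measured step replaces cyclobutyl with phenyl, and its floor of an at least 2.0-fold higher number from compound 1 to compound 2 (0.30 log units; that floor lies within the scatter) lies within the scatter, so it gives no direction for a smaller ring. On this basis the expected step of a 1.0-fold higher number from compound 1 to compound 4 (0.00 log units; within the scatter) is none beyond the scatter. Compound 4 is therefore estimated at 25000 nM in this assay, with a range from 10000 nM to 60000 nM.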

Compound 4, half-maximal inhibitory concentration: 3680 nM
Compound 4: middle estimate off by 6.8-fold (0.83 log units), on the high side; the measured number lies below the stated range.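

In this assay, within the data shown here, the amide-type nitrogen responds to a small change in the carbon ring: cyclopropyl in place of cyclobutyl gives a 6.7-fold lower number from compound 1 to compound 4 (0.83 log units; beyond the scatter), the first step that is beyond the scatter and has a definite number at both ends. Cyclopropyl in place of phenyl at the same nitrogen gives an at least 13-fold lower number from compound 2 to compound 4 (1.13 log units; beyond the scatter), which leaves compound 4 with the lowest number among the entries with a reading, whereas the earlier comparison gave no direction for a smaller ring. This second step is known only as a floor, since compound 2 stands at a limit of the assay: the limit of > 50000 nM in this assay, at which 1 of the 4 values shown sits.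

The compounds shown do not explain why the cyclopropyl compound gives the lower number, and two carbon rings are too few to establish a trend with ring size. From the compounds shown here alone, it also remains open whether an open-chain group such as ethyl or isopropyl, a larger ring such as cyclohexyl, or a ring carrying an amine would follow cyclopropyl or cyclobutyl at this nitrogen.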